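Swapping one aryl group for another on the anilino nitrogen

The source may report more compounds than this note shows. Statements on the series, on what has been measured and on what is new or still open speak of the compounds shown alone.

In a functional assay on HeLa cells (Homo sapiens) for inhibition, read by sulforhodamine B assay (on this read-out higher numbers stand for weaker inhibition and lower numbers for stronger inhibition), compound 2 `Cc1ccc(NC2=CC(=O)c3c(nc4n3[C@H]3OC[C@@H](O)[C@H]3OC4)C2=O)cc1C` gives 4320 nM, the lowest of the two numbers in hand. Compound 1 `O=C1C(Nc2cccc(Cl)c2)=CC(=O)c2c1nc1n2[C@H]2OC[C@@H](O)[C@H]2OC1` gives 7970 nM, and a 1.8-fold lower number from compound 1 to compound 2 (0.27 log units; within the scatter). Compound 3 `O=C1C(N2CCCCC2)=CC(=O)c2c1nc1n2[C@H]2OC[C@@H](O)[C@H]2OC1` gives > 16000 nM, which is a limit of the assay rather than a number (the limit of > 16000 nM in this assay, at which 1 of the 3 values shown sits). Replacing the arylamino group by piperidin-1-yl produced an at least 2.0-fold higher number from compound 1 to compound 3 (0.30 log units; that floor lies within the scatter) and an at least 3.7-fold higher number from compound 2 to compound 3 (0.56 log units; beyond the scatter).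

Compound 4 `CCOc1ccc(NC2=CC(=O)c3c(nc4n3[C@H]3OC[C@@H](O)[C@H]3OC4)C2=O)cc1` is not yet measured; it differs from compound 2 by 4-ethoxyphenyl in place of 3,4-dimethylphenyl on an amine nitrogen. Going by the values given here, the one measured step that bears on this change is the exchange of one aryl group for another on the amine nitrogen, a 1.8-fold lower number from compound 1 to compound 2 (0.27 log units; within the scatter), which stayed within the scatter. The steps to piperidin-1-yl alter the nitrogen itself rather than the aryl group and so say little here. The change from compound 2 to compound 4 is therefore expected to give a step of a 1.2-fold higher number from compound 2 to compound 4 (0.06 log units; within the scatter) that does not go beyond the scatter. Compound 4 is estimated at 5000 nM, between 2000 nM and 14000 nM.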

Compound 4, half-maximal inhibitory concentration: 14400 nM
Compound 4: the middle estimate sits 2.9-fold (0.46 log units) below what was measured; the measured number lies above the stated range.
By their numbers in this assay, from the lowest: compounds 2, 1 and 4 (each within the scatter of the next, the first and the last beyond it). At a limit, above all of these: compound 3.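

Going by these compounds alone, the aryl group on the amine nitrogen can matter: in this assay, 4-ethoxyphenyl in place of 3,4-dimethylphenyl gave a 3.3-fold higher number from compound 2 to compound 4 (0.52 log units; beyond the scatter), the only exchange of one aryl group for another here that goes beyond the scatter. 4-Ethoxyphenyl in place of 3-chlorophenyl gave a 1.8-fold higher number from compound 1 to compound 4 (0.26 log units; within the scatter), so the size of such a step depends on which two aryl groups are exchanged. No measurement shown explains the larger step.

3,4-Dimethylphenyl and 4-ethoxyphenyl differ both in their substituents and in where these sit on the ring, and the compounds shown do not separate the two. Also open, on these data alone, is what an unsubstituted phenyl, a 4-methoxyphenyl or a 4-hydroxyphenyl group on the same nitrogen would give.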